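The compounds below may be only part of what the source reports. "The series", "measured", "known", "first", "only" and "open" are said of these compounds alone.

Working notes on the series. Compound 1 `COc1ccc(/C=C\c2cc(OC)c(OC)c(OC)c2)cc1OCc1ccc(CN2CC[C@@H](O)C2)cc1` is one of three congeners measured in a functional assay on B16-F10 cells (Mus musculus) for antiproliferative activity, read by CCK-8 assay, with a stated time of 48 h; on this read-out lower numbers stand for stronger inhibition and higher numbers for weaker inhibition. In this assay compound 1 gives > 10000 nM, which is a limit rather than a number. Compound 2 `COc1ccc(/C=C\c2cc(OC)c(OC)c(OC)c2)cc1OCc1ccc(CN2CC[C@@H](C(=O)O)C2)cc1` gives > 10000 nM in this assay, again a limit. Compound 3 `COc1ccc(/C=C\c2cc(OC)c(OC)c(OC)c2)cc1OCc1ccc(CN2CCCCC2C(=O)NCCN)cc1` gives 4600 nM in this assay, the only number shown among the three values; the other two values sit at the limit of > 10000 nM in this assay, at which 2 of the 3 values shown sit. The step that the two limits leave unreadable from compound 1 to compound 2 cannot be read, since both ends are limits. The steps of an at least 2.1-fold lower number from compound 1 to compound 3 (0.33 log units; beyond the scatter) and an at least 2.1-fold lower number from compound 2 to compound 3 (0.33 log units; beyond the scatter) are the only readable ones, and both point the same way.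

Compound 4 `COc1ccc(/C=C\c2cc(OC)c(OC)c(OC)c2)cc1OCc1ccc(CN[C@H](C(=O)O)[C@@H](C)O)cc1` is not yet measured. Its change from compound 3 is (1-carboxy-2-hydroxypropyl)amino in place of 2-((2-aminoethyl)carbamoyl)piperidin-1-yl on a saturated chain carbon bound to an aromatic carbon. The two readable steps bear directly on this change: moving from a 3-hydroxypyrrolidin-1-yl or a 3-carboxypyrrolidin-1-yl group to the 2-((2-aminoethyl)carbamoyl)piperidin-1-yl group lowered the number in this assay at least modestly. Compound 4 reverses that move, returning to an acyclic group carrying carboxy and hydroxy as compounds 1 and 2 do, so the expected step in this assay is a 1.7-fold higher number from compound 3 to compound 4 (0.24 log units; within the scatter), back toward the limit. For compound 4 the estimate in this assay is 8000 nM, with a range from 3000 nM to 20000 nM, and a real chance that only a limit is reported.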

Compound 4, half-maximal inhibitory concentration: 5400 nM
Compound 4: the middle estimate sits 1.5-fold (0.17 log units) above what was measured, and the stated range covers the measured number.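

In this assay, the (1-carboxy-2-hydroxypropyl)amino group and the 2-((2-aminoethyl)carbamoyl)piperidin-1-yl group are not separated at this saturated chain carbon bound to an aromatic carbon, with a 1.2-fold higher number from compound 3 to compound 4 (0.07 log units; within the scatter), so a measurable value here does not depend on the piperidine-based group or on keeping a six-membered non-aromatic ring at this place. The comparisons with the two limit compounds give an at least 1.8-fold lower number from compound 2 to compound 4 (0.26 log units; that floor lies within the scatter) and an at least 1.8-fold lower number from compound 1 to compound 4 (0.26 log units; that floor lies within the scatter), so although compound 4 returns a number, neither floor sets it clearly apart from the compounds carrying the 3-carboxypyrrolidin-1-yl and 3-hydroxypyrrolidin-1-yl groups. Compound 2 and compound 4 both carry a carboxy group, yet only compound 4 gives a number, so the presence of carboxy does not by itself decide the outcome at this place.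

Going by these compounds, the step between compound 1 and compound 2 cannot be read, and the true size of the gaps to both compounds remains unknown: the limit of > 10000 nM in this assay, at which 2 of the 4 values shown sit. Whether an open-chain 2-aminoethylamino group or a morpholin-4-yl group at this place would move the number beyond the scatter from compound 3 remains open.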